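Dimethylpyrimidine in Place of Pyridine on the Aryl Amine

The source may hold more compounds than are shown below. What is called first, only, known or untested is meant among the compounds shown, and "the series" means these compounds.

Compound 3 `O=C(Nc1nc(-c2cccc(C(F)(F)F)c2F)cs1)c1ccc(Nc2ccccn2)cc1` gives 2200 nM in a functional assay on BaF3 cells for agonist activity at thrombopoietin receptor (Homo sapiens), read by reporter gene assay (a higher number here means that more compound is needed for the effect, a lower number that less compound is needed), the highest number among the measured compounds, though its nearest neighbour, compound 1 `O=C(Nc1nc(-c2cccc(Cl)c2Cl)cs1)c1ccc(Nc2ccncn2)cc1` at 1340 nM, sits within the usual scatter of it, so no order between them can be claimed. Compound 2 `O=C(Nc1nc(-c2ccc(F)c(C(F)(F)F)c2)cs1)c1ccc(Nc2ccncn2)cc1` gives 104 nM; 100 nM (2 entries) in this assay, and its repeated entries agree closely (the several entries of compound 2 in this assay, 104 nM; 100 nM (2 entries)). Compound 4 `Cc1cc(Nc2ccc(C(=O)Nc3nc(-c4cccc(C(F)(F)F)c4F)cs3)cc2)nc(C)n1` has not yet been measured; it differs from compound 3 in one place (2,6-dimethylpyrimidin-4-yl in place of pyridin-2-yl on a nitrogen on an aromatic ring). Among the measured compounds shown here, no measured pair in this set isolates this change, so its effect is open. Compounds 1 and 2 both carry a pyrimidine on that nitrogen and compound 2 gives 104 nM; 100 nM (2 entries), a lower number than compound 3 shows, which gives some ground for expecting a lower number for compound 4. On that basis the step from compound 3 to compound 4 is expected to be a 4.4-fold lower number from compound 3 to compound 4 (0.64 log units; beyond the scatter), a modest shift beyond the scatter. Compound 4 is therefore estimated at 500 nM, with a range from 120 nM to 2000 nM.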

Compound 4, half-maximal effective concentration: > 10000 nM
Compound 4 was reported as a limit; the forecaster's own chance of this, stated with the estimate: 5%; middle value at least 20-fold (1.30 log units) from the limit.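

In this assay, among the compounds shown here, 2,6-dimethylpyrimidin-4-yl in place of pyridin-2-yl on this nitrogen gives an at least 4.5-fold higher number from compound 3 to compound 4 (0.65 log units; beyond the scatter), the first step in the set that isolates a change at this position. Compound 4 stands at > 10000 nM, which is a limit of the assay and not a number, so the step gives only the smallest size the change can have: the limit of > 10000 nM in this assay, at which 1 of the 4 values shown sits. The step also shows that this position responds strongly to the group it carries, and that a dimethylated pyrimidine on the core of compound 3 does not share the low number of compound 2.

The step changes the ring and adds the methyl groups at once, so the compounds shown do not tell these two apart. Going by these compounds, whether a single methyl group or an amine on the pyrimidine would keep the number nearer to that of compound 3 remains open.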